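Boc on the amide nitrogen across two related cores

The source may hold more compounds than are shown below. What is called first, only, known or untested is meant among the compounds shown, and "the series" means these compounds.

Measured so far:
- compound 1 `CC(C)(C)OC(=O)N(Cc1ccco1)C(=O)c1ccc(Cn2c(=O)c3ccccc3[s+]2[O-])cc1`: 87300 nM
- compound 2 `O=C(NCc1ccco1)c1ccc(Cn2c(=O)c3ccccc3[s+]2[O-])cc1`: > 100000 nM
- compound 3 `CNC(=O)c1ccc(CN2C(=O)c3ccccc3S2(=O)=O)cc1`: > 100000 nM

Working notes. The read-out is an ADME assay on RAW264.7 cells (Mus musculus) for cytotoxicity, read by WST assay; on this read-out higher numbers stand for lower toxicity in this test and lower numbers for higher toxicity in this test. In this assay compound 1 gives 87300 nM. For compound 2 this assay reports only a limit, > 100000 nM. For compound 3 the same assay also reports only a limit, > 100000 nM. Two of the three values sit at the same ceiling (the limit of > 100000 nM in this assay, at which 2 of the 3 values shown sit), so the series is largely flat at the top of the measurable range.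

Among the measured compounds shown here, the one measured step is an at least 1.1-fold lower number from compound 2 to compound 1 (0.05 log units; that floor lies within the scatter), the change being (tert-butoxycarbonyl in place of hydrogen on an amide-type nitrogen). It falls within the scatter and is bounded on one side by the limit of compound 2.

Compound 4 `CN(C(=O)OC(C)(C)C)C(=O)c1ccc(CN2C(=O)c3ccccc3S2(=O)=O)cc1` is not yet measured. It carries the same change on the core of compound 3: tert-butoxycarbonyl in place of hydrogen on an amide-type nitrogen. The two place lines read the same, so this is the same change, made on a different core; how the core of compound 3 differs from that of compound 2 is not broken down here.

Expectation for compound 4 in this assay: a step of about an at least 1.1-fold lower number from compound 3 to compound 4 (0.04 log units; that floor lies within the scatter), set beside the earlier step, because the same change gave an at least 1.1-fold lower number from compound 2 to compound 1 (0.05 log units; that floor lies within the scatter), which stayed within the scatter. Compound 4 is therefore expected near 90000 nM, with a range of 40000 nM to 150000 nM, and a real chance that the assay again returns only a limit.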

Compound 4, concentration lethal to 50% of the cells: > 100000 nM
Compound 4 gave a limit, no number; the forecaster's own chance of this, stated with the estimate: 50%; at least 1.1-fold (0.04 log units) between middle value and limit.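

In this assay, among the compounds shown here, compound 3 and compound 4 both return only limits, not numbers, so no step between them can be read. The compounds shown leave open what size of change, if any, tert-butoxycarbonyl in place of hydrogen on an amide-type nitrogen brings on either core, with most of the series resting at a single ceiling: the limit of > 100000 nM in this assay, at which 3 of the 4 values shown sit.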